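Replacing the furan ring: an expectation for compound 4

This account rests on a few compounds, and the source may have more. Where it says the series, first, only, none or still open, it means among the compounds named here.

Compound 1 `CC(=O)O[C@@H]1CC[C@]2(C)C(CCc3ccoc3)=C(C)C(=O)[C@@H](O)[C@H]2C1(C)C`: 22500 nM
Compound 2 `CC1=C(CCc2ccoc2)[C@@]2(C)CCC(=O)C(C)(C)C2=C(O)C1=O`: > 50000 nM (a limit of the assay, not a number)
Compound 3 `CCOC1CC(O)(CCC2=C(C)C(=O)C(O)=C3C(C)(C)C(=O)CC[C@]23C)CO1`: 22900 nM

All three were measured in a functional assay on RAW264.7 cells (Mus musculus) for inhibition, read by Griess assay, with stated times of 2 h and 18 h; on this read-out lower numbers stand for stronger inhibition and higher numbers for weaker inhibition. Compound 2 reached only the limit (the limit of > 50000 nM in this assay, at which 1 of the 3 values shown sits). Compound 3 carries 5-ethoxy-3-hydroxyoxolan-3-yl in place of furan-3-yl on a saturated chain carbon, two bonds along the chain from a double-bonded ring carbon, and this gave an at least 2.1-fold lower number from compound 2 to compound 3 (0.33 log units; beyond the scatter). Compound 1 and compound 3 sit within the scatter of each other, so no order between them is claimed. How the core of compound 1 differs from the core of compound 2 is not broken down here.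

Compound 4 `CCOC1CC(O)(CCC2=C(C)C(=O)[C@@H](O)[C@H]3C(C)(C)[C@H](OC(C)=O)CC[C@]23C)CO1` is not yet measured. Among the compounds with values here, it differs from compound 1 by 5-ethoxy-3-hydroxyoxolan-3-yl in place of furan-3-yl on a saturated chain carbon, two bonds along the chain from a double-bonded ring carbon, the same change as the one from compound 2 to compound 3. Because compound 1 already gives 22500 nM and compound 3 gives 22900 nM, a step of about the earlier size would carry compound 4 only somewhat lower, and the step is expected to be a 1.5-fold lower number from compound 1 to compound 4 (0.18 log units; within the scatter). Compound 4 is therefore estimated at 15000 nM, with a range from 6000 nM to 40000 nM expected to hold most repeats.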

Compound 4, half-maximal inhibitory concentration: 30400 nM
Compound 4: the middle estimate sits 2.0-fold (0.31 log units) below what was measured, and the stated range covers the measured number.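

In this assay, putting 5-ethoxy-3-hydroxyoxolan-3-yl in place of furan-3-yl on the core of compound 1 gave a 1.4-fold higher number from compound 1 to compound 4 (0.13 log units; within the scatter), a step that stays within the scatter. The change therefore did not carry over from one core to the other with the same size: the same change on two cores in this assay, an at least 2.1-fold lower number (0.33 log units; beyond the scatter) from compound 2 to compound 3 and a 1.4-fold higher number (0.13 log units; within the scatter) from compound 1 to compound 4, at least 2.9-fold (0.46 log units) apart, beyond the scatter of two such steps Compound 2 stands at a limit of the assay and not at a number, so the comparison fixes no exact size for the earlier step and does not show which difference between the two cores is responsible: the limit of > 50000 nM in this assay, at which 1 of the 4 values shown sits.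

The compounds shown carry the ethoxy and hydroxy parts of the new ring only together, so what each part contributes on either core remains open. Also open, from the compounds shown here alone, is how a ring bearing an amine or a carboxylic acid in place of the ethoxy would behave on these two cores.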